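Replacing benzyloxycarbonyl in a compound at the assay limit

The compounds below may be only part of what the source reports. "The series", "measured", "known", "first", "only" and "open" are said of these compounds alone.

In an ADME assay on microsomes from liver (Homo sapiens) for metabolic stability, read by LC-MS, with NADPH named in the record, with a stated time of 60 min, tested at 1 uM, in the absence of a further agent (a lower number here means that less of the compound is left, a higher number that more of the compound is left), compound 1 (`COc1ccc(-c2c(C)nc3c(N4CC[C@@H](NC(=O)OCc5ccccc5)C4)cc(C)nn23)cc1OC`) gives > 95% as its result, and this is a limit of the assay, not a number. Compound 2 (`COc1ccc(-c2c(C)nc3c(N4CC[C@@H](NC(=O)Oc5ccc6ccccc6c5)C4)cc(C)nn23)cc1OC`) likewise gives > 95% as a limit. The evidence so far is short: the limit of > 95% in this assay, at which 2 of the 2 values shown sit, and no result lies anywhere else.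

Compound 3 (`COc1ccc(-c2c(C)nc3c(N4CC[C@@H](NS(=O)(=O)c5ccc(C)cc5)C4)cc(C)nn23)cc1OC`) carries (4-methylphenyl)sulfonyl in place of benzyloxycarbonyl on an amine nitrogen. Going by the values given here, the only measured step is a step that the two limits leave unreadable from compound 1 to compound 2 and it puts naphthalen-2-yl in place of benzyl on an oxygen next to a carbonyl group. Among the compounds with values here, it gives no size to carry over, and no measured step covers a sulfonyl group. Compound 2 still reaches its limit of > 95% after a change within the departing group, so no shift beyond the usual scatter is expected in this assay here. The estimated step is a number at least 3 percentage points lower from compound 1 to compound 3 (that floor lies within the scatter) and any real movement is expected to be downward. For compound 3 the estimated value is 92% with an expected range from 72% to 100% and a report as a limit is quite likely.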

Compound 3, percent of the compound remaining: > 95%
Compound 3 was reported as a limit; the forecaster's own chance of this, stated with the estimate: 55%; middle value at least 3 percentage points away from the limit.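

Compound 1 and compound 3 both stand at a limit in this assay, not at a number, so the step between them cannot be read. The compounds shown leave open whether any group on the amine nitrogen would leave less of the compound remaining, for all three share one result: the limit of > 95% in this assay, at which 3 of the 3 values shown sit.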